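The source may report more compounds than this note shows. Statements on the series, on what has been measured and on what is new or still open speak of the compounds shown alone.

Measured so far in a functional assay on MCF7 cells (Homo sapiens) for inhibition, read by MTT assay, with a stated time of 72 h; a higher number here means a weaker inhibitor, a lower number a stronger inhibitor:
Compound 1 `C=C[C@]1(C)C[C@@H](OC(=O)CNC(=O)Nc2cccc(Br)c2)[C@]2(C)[C@H](C)CC[C@]3(CCC(=O)[C@H]32)[C@@H](C)[C@@H]1O`: > 10000 nM
Compound 2 `C=C[C@]1(C)C[C@@H](OC(=O)CNC(=O)Nc2ccc(F)cc2)[C@]2(C)[C@H](C)CC[C@]3(CCC(=O)[C@H]32)[C@@H](C)[C@@H]1O`: > 10000 nM

Compound 2 gives > 10000 nM, which is a limit of this assay and not a number. Compound 1 gives > 10000 nM, which is also a limit. The whole picture so far is the limit of > 10000 nM in this assay, at which 2 of the 2 values shown sit.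

Compound 3 `C=C[C@]1(C)C[C@@H](OC(=O)CNC(=O)Nc2ccccc2Br)[C@]2(C)[C@H](C)CC[C@]3(CCC(=O)[C@H]32)[C@@H](C)[C@@H]1O` has the shared core and differs from compound 2 in one place: 2-bromophenyl in place of 4-fluorophenyl on an amide-type nitrogen. In words, 2-bromophenyl stands in place of 4-fluorophenyl on an amide-type nitrogen.

Going by the values given here, the only measured step that bears on this change is a step that the two limits leave unreadable from compound 1 to compound 2. It offers no size to carry over, and neither the 3-bromophenyl of compound 1 nor the 4-fluorophenyl of compound 2 produced a number. With no measured sign of activity to build on, no clear gain is expected in this assay. The expected change is a step that the limit leaves unreadable from compound 2 to compound 3, an estimate with no firm direction. For compound 3 the estimate is 15000 nM, with an expected range from 6000 nM to 40000 nM. Another result given only as a limit is the likeliest outcome.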

Compound 3, half-maximal inhibitory concentration: > 10000 nM
Compound 3: only a limit was reported (the forecaster's own chance of this, stated with the estimate: 85%); the middle value lies beyond the limit too.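

In this assay compound 3 gives > 10000 nM as a limit and not a number. Going by these compounds alone, no step among compound 1, compound 2 and compound 3 can be read, and the picture stays the same: the limit of > 10000 nM in this assay, at which 3 of the 3 values shown sit. Still open, from the compounds shown here alone, is whether, in this assay, any other group on this amide-type nitrogen would give a measurable value.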